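The compounds below may be only part of what the source reports. "The series", "measured", "known", "first", "only" and "open" are said of these compounds alone.

In a functional assay on SNB-75 cells (Homo sapiens) for inhibition, read by colorimetric assay and sulforhodamine B assay, with a stated time of 48 h (on this read-out higher numbers stand for weaker inhibition of growth and lower numbers for stronger inhibition of growth), compound 1 `CCCCCCCCCCCC[C@@H](O)[C@H]1CC[C@H]([C@H](O)CCCCCCCCCCNC(=O)c2ccco2)O1`, which carries a furan-2-yl group on the carbonyl carbon of its amide, gives 100000 nM. Compound 2 `CCCCCCCCCCCC[C@@H](O)[C@H]1CC[C@H]([C@H](O)CCCCCCCCCCNC(=O)c2ccoc2)O1`, with furan-3-yl in that place, gives 100000 nM, and moving between the two furans produces no change at the digits printed from compound 1 to compound 2 (within the scatter). Compound 3 `CCCCCCCCCCCC[C@@H](O)[C@H]1CC[C@H]([C@H](O)CCCCCCCCCCNC(=O)c2ccsc2)O1`, with thiophen-3-yl, gives 2820 nM, the lowest of the three numbers and so the strongest growth inhibition seen in this small set. Its distance from the furans appears as a 35-fold lower number from compound 1 to compound 3 (1.55 log units; beyond the scatter) and as a 35-fold lower number from compound 2 to compound 3 (1.55 log units; beyond the scatter).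

Compound 4 `CCCCCCCCCCCC[C@@H](O)[C@H]1CC[C@H]([C@H](O)CCCCCCCCCCNC(=O)c2ccnn2C)O1` keeps the shared core and the amide but changes the ring: 1-methyl-1H-pyrazol-5-yl in place of thiophen-3-yl on a carbonyl carbon. This places 1-methyl-1H-pyrazol-5-yl where thiophen-3-yl stood on the carbonyl carbon. Among the compounds with values here, no measured compound carries a pyrazole, so the evidence is indirect. Both measured replacements of the thiophen-3-yl ring differ from compound 3 by a large gap, seen in a 35-fold lower number from compound 2 to compound 3 (1.55 log units; beyond the scatter), and the new ring, like the furans, contains no sulfur. A clear move towards weaker inhibition therefore seems more likely than a match with compound 3, though probably not the full distance to the furans. The expected step is a 7.1-fold higher number from compound 3 to compound 4 (0.85 log units; beyond the scatter). For compound 4 the estimated value is 20000 nM, with an expected range from 3000 nM to 100000 nM.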

Compound 4, concentration for 50% growth inhibition: 50100 nM
The estimate for compound 4 lay 2.5-fold (0.40 log units) below the measured number; the measured number falls inside the stated range.
By their numbers in this assay, from the lowest: compound 3; then compounds 4, 1 and 2 (each within the scatter of the next).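

In this assay, 1-methyl-1H-pyrazol-5-yl in place of thiophen-3-yl on the carbonyl carbon gives an 18-fold higher number from compound 3 to compound 4 (1.25 log units; beyond the scatter), so a five-membered aromatic ring at this place is not enough to keep the stronger growth inhibition of compound 3. Against the furans the steps read a 2.0-fold lower number from compound 2 to compound 4 (0.30 log units; within the scatter) and a 2.0-fold lower number from compound 1 to compound 4 (0.30 log units; within the scatter), which leaves compound 4 indistinguishable from both and makes thiophen-3-yl the only one of the four rings that stands apart. That ring is also the only one with sulfur, but a single compound cannot establish that sulfur matters, and no measurement is available that explains the difference between the rings.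

The compounds leave open whether thiophen-2-yl, or a six-membered ring such as phenyl or pyridin-3-yl, would match compound 3 or fall back with the others. Also open, going by these compounds, is whether the advantage of thiophen-3-yl would survive with a shorter chain linking the amide to the shared core.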